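This account rests on a few compounds, and the source may have more. Where it says the series, first, only, none or still open, it means among the compounds named here.

Measured in a functional assay on CHO cells for antagonist activity at prostaglandin E2 receptor EP4 subtype (Homo sapiens), read by calcium flux, with a stated time of 15 min; a lower number here means a stronger inhibitor, a higher number a weaker inhibitor:
Compound 1, `CCCc1c(C(=O)N[C@@H](C)c2ccc(C(=O)O)cc2)nnn1Cc1ccc(C(F)(F)F)cc1`, gives > 10000 nM, which is a limit of this assay and not a number.
Compound 2, `CCCc1nnn(Cc2ccc(C(F)(F)F)cc2)c1C(=O)N[C@@H](C)c1ccc(C(=O)O)cc1`, gives 68.8 nM.
Compound 3, `C[C@H](NC(=O)c1c(-c2ccccc2)nnn1Cc1ccc(F)cc1)c1ccc(C(=O)O)cc1`, gives 330 nM.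

Of the two numbers, compound 2 stands lowest; its nearest neighbour, compound 3, lies beyond the scatter from it. Compound 1 has the propyl and the amide exchanged on the shared core relative to compound 2, and for compound 1 only a limit was reached (the limit of > 10000 nM in this assay, at which 1 of the 3 values shown sits). Compound 3 carries a phenyl where compound 2 has the propyl, and at the same time a 4-fluorobenzyl in place of the 4-(trifluoromethyl)benzyl, so its value cannot be tied to a single change.

Compound 4, `C[C@H](NC(=O)c1c(C2=CCOCC2)nnn1Cc1ccc(C(F)(F)F)cc1)c1ccc(C(=O)O)cc1`, is not yet measured. It differs from compound 2 by a group of 6 heavy atoms (5 carbon, 1 oxygen; one six-membered non-aromatic ring with 1 hetero atom) in place of a group of 3 heavy atoms (3 carbon; no ring), on an aromatic carbon. Going by the values given here, no measured pair differs only at this point. The expectation for compound 4 rests on compound 3, whose phenyl at the same place gives 330 nM alongside a different benzyl group. The step of a 1.7-fold higher number from compound 2 to compound 4 (0.24 log units; within the scatter) is expected to be a modest loss, at the edge of the scatter. The estimate for compound 4 in this assay is 120 nM, with a range from 35 nM to 450 nM.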

Compound 4, half-maximal inhibitory concentration: 119 nM
The estimate for compound 4 lay 1.0-fold (0.00 log units) above the measured number, and the stated range covers the measured number.
By their numbers in this assay, from the lowest: compounds 2 and 4 (each within the scatter of the next); then compound 3. At a limit, above all of these: compound 1.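

In this assay the propyl gives way to a six-membered non-aromatic ring with 1 hetero atom, and this exchange gives a 1.7-fold higher number from compound 2 to compound 4 (0.24 log units; within the scatter) and so does not separate the two compounds. This is the first pair shown that differs in one place only, and it shows that this aromatic carbon, next to the ring atom that bears a large group, accepts a group of 6 heavy atoms in place of a group of 3 heavy atoms with a number still within the scatter. Both compounds keep the 4-(trifluoromethyl)benzyl group, so this step, unlike the value of compound 3, can be tied to a single change.

The compounds shown leave open which part of the entering group counts at this position: its ring oxygen, which a carbon could replace, its double bond, which a saturated tetrahydropyran ring would lack, or simply its size, which a longer chain such as butyl would test. No measurement shown bears on why the propyl and the ring group give numbers this close.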